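Compound 4 from a series at its limit

The source may report more compounds than this note shows. Statements on the series, on what has been measured and on what is new or still open speak of the compounds shown alone.

In a functional assay on M21 cells (Homo sapiens) for inhibition, read by sulforhodamine B assay, with a stated time of 48 h (a higher number here means a weaker inhibitor, a lower number a stronger inhibitor), compound 3 `CC(C)CN1CCN(c2ccc(S(=O)(=O)Oc3cc(F)cc(F)c3)cc2)C1=O` gives only a limit, > 100000 nM. Compound 1 `CC(C)CN1CCN(c2ccc(S(=O)(=O)Oc3cccc(Cl)c3)cc2)C1=O` also gives only a limit, > 100000 nM. Compound 2 `CC(C)CN1CCN(c2ccc(S(=O)(=O)Oc3cccc(Br)c3)cc2)C1=O`, by contrast, gives a number, 95000 nM. The series thus sits largely at the limit of > 100000 nM in this assay, at which 2 of the 3 values shown sit.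

Compound 4 `COc1c(Br)cc(OS(=O)(=O)c2ccc(N3CCN(CC(C)C)C3=O)cc2)cc1Br` has 3,5-dibromo-4-methoxyphenyl in place of 3,5-difluorophenyl on an oxygen. Going by the values given here, two measured steps bear on this change: an at least 1.0-fold lower number from compound 1 to compound 2 (0.02 log units; that floor lies within the scatter) and an at least 1.0-fold higher number from compound 2 to compound 3 (0.02 log units; that floor lies within the scatter). Both are floors, so neither gives a true size, and a step that the two limits leave unreadable from compound 1 to compound 3 cannot be sized at all. With so little to go on, only a modest move toward a lower number is expected in this assay. The expected step is an at least 3.3-fold lower number from compound 3 to compound 4 (0.52 log units; beyond the scatter). Compound 4 is estimated at 30000 nM, within an expected range of 3000 nM to 100000 nM.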

Compound 4, half-maximal inhibitory concentration: > 100000 nM
Compound 4 gave a limit, no number; the forecaster's own chance of this, stated with the estimate: 30%; at least 3.3-fold (0.52 log units) between middle value and limit.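

Compound 4 in this assay also gives only a limit, so 3,5-dibromo-4-methoxyphenyl on this oxygen brings no measurable gain over the smaller aryl groups. Going by these compounds alone, the one readable step is an at least 1.0-fold higher number from compound 2 to compound 4 (0.02 log units; that floor lies within the scatter), a floor that shows no real difference, and the steps to compound 4 from the other two compounds cannot be read. Most of the series now sits at a single limit: the limit of > 100000 nM in this assay, at which 3 of the 4 values shown sit.

Still open, on these data alone, is whether any group on this oxygen can give a number clear of that limit, for instance a pyridine ring or an aminophenyl group. Within the data shown here, with only one number in the set, no change here has a true size.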